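Swapping the Five-Membered Ring on a Shared Core

The compounds below may be only part of what the source reports. "The series", "measured", "known", "first", "only" and "open" are said of these compounds alone.

Measured so far:
Compound 1, `Cc1n[nH]c(-c2ccccc2NCC2=NCCN2)n1`, gives 87% in a functional assay with Alpha-1A adrenergic receptor (Homo sapiens) as the target, read by calcium flux; a higher number here means a larger maximal response, a lower number a smaller maximal response.
Compound 2, `c1ccc(-c2cn[nH]c2)c(NCC2=NCCN2)c1`, gives 112% in this assay.

Among the measured compounds shown here, compound 2 stands highest of the two numbers measured; the only neighbour is compound 1, and the step of a number 25 percentage points higher from compound 1 to compound 2 (beyond the scatter) lies beyond the scatter, so the two do differ. Both share the same core and differ only in the ring attached to it.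

Compound 3, `Cn1ccnc1-c1ccccc1NCC1=NCCN1`, is not yet measured. It differs from compound 2 in one place: 1-methyl-1H-imidazol-2-yl in place of 1H-pyrazol-4-yl on an aromatic carbon. For the measured compounds named here, the only measured step that bears on this change is the one from compound 1 to compound 2, which also swapped one ring for another at the same place and gave a number 25 percentage points higher from compound 1 to compound 2 (beyond the scatter), a modest shift. That step tells how much such a swap can move the response, but not in which direction a third ring will go. A shift of similar or smaller size in this assay is therefore expected, with the direction open and a downward lean. For compound 3 the estimate is 95%, between 70% and 120%, meaning an expected step of a number 17 percentage points lower from compound 2 to compound 3 (beyond the scatter).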

Compound 3, largest response reached (reported as maximal response), in percent of the reference or control that the assay uses: 88%
Estimate against measurement, compound 3: 7 percentage points above, and the stated range covers the measured number.
By their numbers in this assay, from the lowest: compounds 1 and 3 (each within the scatter of the next); then compound 2.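

Replacing 1H-pyrazol-4-yl with 1-methyl-1H-imidazol-2-yl on the aromatic carbon gives a number 24 percentage points lower from compound 2 to compound 3 (beyond the scatter) in this assay and so shows that the response at this position can fall as well as rise when one five-membered aromatic ring replaces another. Among the compounds shown here, the comparison of the two lower compounds, a number 1 percentage points higher from compound 1 to compound 3 (within the scatter) in the same assay, shows that two different rings can give responses that cannot be told apart, leaving 1H-pyrazol-4-yl as the only one of the three rings that stands apart. The swap from compound 2 to compound 3 changes several things at once, going from 5 heavy atoms to 6 and from 1 hydrogen-bond donor to 0, and no measurement here shows which of these changes matters.

The compounds shown leave open whether the added methyl or the different arrangement of the ring atoms accounts for the lower response, a question that the parent 1H-imidazol-2-yl ring without the methyl could help to settle. They also leave open how a non-ring group at this position, such as an amine or a carboxylic acid, would compare with these three rings.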